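Proline-nitrile series: ring-opened amide at the carbonyl

The source may hold more compounds than are shown below. What is called first, only, known or untested is meant among the compounds shown, and "the series" means these compounds.

Measured so far:
- compound 1, `CCC[C@@H]1CN[C@H](C(=O)N2CCC[C@H]2C#N)C1`: 50%
- compound 2, `C[C@@H]1N[C@H](C(=O)N2CCC[C@H]2C#N)C[C@@H]1C(=O)N1CCC1`: 94%

In an assay on the whole organism (plasma, strain Sprague-Dawley) for inhibition of Dipeptidyl peptidase 4 (Rattus norvegicus), with a stated time of 6 h, at a dose of 1 mg/kg by the oral route (on this read-out lower numbers stand for less inhibition and higher numbers for more inhibition at the one dose given (going by the name of the read-out)), compound 2 gives 94%, the higher of the two numbers; compound 1 gives 50% in this assay, a gap beyond the usual scatter. Compound 2 thus stands at the top of the pair.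

Compound 3, `CCN(C)C(=O)[C@H]1C[C@@H](C(=O)N2CCC[C@H]2C#N)N[C@H]1C`, is unmeasured. It differs from compound 2 at one place: ethyl(methyl)amino in place of azetidin-1-yl on a carbonyl carbon. The group that leaves and the group that enters have the same heavy-atom count and the same absence of donors and acceptors; the four-membered ring is simply opened into an acyclic amine on the carbonyl carbon.

Among the measured compounds shown here, no measured pair isolates this kind of change, so the expectation rests on compound 2 alone. A small step is expected, at most modestly downward, and quite possibly none beyond the scatter, since compound 2 gives 94% and the amide substitution keeps the counted composition. The expected step is a number 9 percentage points lower from compound 2 to compound 3 (within the scatter). Compound 3 is estimated at 85%, with a range from 65% to 97%.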

Compound 3, a percentage reported as inhibition, in the whole organism at one dose (the size of the read-out at that dose, not a potency): 92%
The estimate for compound 3 lay 7 percentage points below the measured number; the measured number falls inside the stated range.
By their numbers in this assay, from the lowest: compound 1; then compounds 3 and 2 (each within the scatter of the next).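

In this assay, opening the four-membered ring of azetidin-1-yl into ethyl(methyl)amino on a carbonyl carbon gives a number 2 percentage points lower from compound 2 to compound 3 (within the scatter). Among the compounds shown here, this is the first matched pair, and it shows that at this one dose the read-out does not depend on the ring being closed, as long as the amine on the carbonyl carbon keeps the same heavy-atom count and composition; compound 2 and compound 3 cannot be told apart here. Nothing available on these compounds bears on the reason for this result.

The compounds shown leave open whether the same holds for other groups on this carbonyl carbon, such as piperidin-1-yl, diethylamino with its longer chains, or the unsubstituted amide, and whether a carboxylic acid could take the place of the amide altogether. They also leave open whether compound 2 and compound 3 would separate at a lower dose or a later time, since a single-dose percentage is not a potency.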